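A few compounds are considered here, and "the series" means these few. Any claim that something is new, unique, unknown or untested is made for them only; others in the source may bear on it.

Measured compounds:
Compound 2, `Cc1ccc(-c2nc3c(=O)n(C)c(=O)n(C)c3[nH]2)cc1`: 0.8 nM
Compound 1, `Cn1c(=O)c2nc(-c3ccc(-c4ccccc4)cc3)[nH]c2n(C)c1=O`: 3.5 nM

For the measured compounds named here, in an assay for binding affinity to adenosine receptor A1 (Bos taurus) (a higher number here means a weaker inhibitor, a lower number a stronger inhibitor), compound 2 gives 0.8 nM, the lowest of the two numbers so far. Its nearest neighbour in this assay is compound 1, which gives 3.5 nM. Going by the values given here, the single measured step, a 4.4-fold lower number from compound 1 to compound 2 (0.64 log units; beyond the scatter), is the only one that bears on the change now considered, since it too alters the group on that aromatic carbon. Compound 3, `CCCCOc1ccc(-c2nc3c(=O)n(C)c(=O)n(C)c3[nH]2)cc1`, has not been measured; it differs from compound 2 by butoxy in place of methyl on an aromatic carbon. Because the step of a 4.4-fold lower number from compound 1 to compound 2 (0.64 log units; beyond the scatter) went to a lower number when the smaller methyl replaced phenyl, putting a larger butoxy in place of the methyl is expected to move the number back up somewhat, though the two groups differ and the size remains uncertain. The step expected for compound 3 is a 3.1-fold higher number from compound 2 to compound 3 (0.49 log units; beyond the scatter). Compound 3 is therefore estimated at 2.5 nM in this assay, with a range from 0.6 nM to 10 nM.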

Compound 3, half-maximal inhibitory concentration: 4 nM
Beside the measured number, compound 3's estimate is 1.6-fold (0.20 log units) below it; low and high end bracket the measured number.
By their numbers in this assay, from the lowest: compound 2; then compounds 1 and 3 (each within the scatter of the next).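

At this aromatic carbon, para to a large group, a second replacement of methyl now gives a higher number in this assay: butoxy in place of methyl produces a step of similar standing to the earlier one (a 5.0-fold higher number from compound 2 to compound 3 (0.70 log units; beyond the scatter)). Butoxy and phenyl are not told apart (a 1.1-fold higher number from compound 1 to compound 3 (0.06 log units; within the scatter)), so among these three compounds only methyl stands apart, even though butoxy has no ring and brings an oxygen. Nothing measured here accounts for these numbers.

The compounds shown do not separate the oxygen of butoxy from its chain, a question that a methoxy group or a plain butyl chain would address. They also leave open how a hydrogen, a fluorine, an amine or a carboxylic acid on this carbon would compare with methyl.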